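Moving the pyridine nitrogen a second time on a shared core

The source may report more compounds than this note shows. Statements on the series, on what has been measured and on what is new or still open speak of the compounds shown alone.

Measured compounds and their values:
- Compound 1 `Cc1cn2c(/C=N/NC(=N)N)c(-c3ccncc3)nc2s1`: 9770 nM
- Compound 2 `Cc1cn2c(/C=N/NC(=N)N)c(-c3cccnc3)nc2s1`: 4790 nM
- Compound 3 `N=C(N)N/N=C/c1c(-c2cccnc2)nc2sc(Cl)cn12`: 13800 nM

All three were tested in a functional assay (Homo sapiens) for antiproliferative activity; on this read-out lower numbers stand for stronger inhibition of growth and higher numbers for weaker inhibition of growth. On these numbers compound 2 stands lowest, that is, it inhibits growth most strongly of the three; its nearest neighbour is compound 1, its furthest compound 3. Two single changes connect them. Swapping the pyridine in compound 1 for the one in compound 2 gave a 2.0-fold lower number from compound 1 to compound 2 (0.31 log units; beyond the scatter). Replacing the methyl on the shared core with chloro gave a 2.9-fold higher number from compound 2 to compound 3 (0.46 log units; beyond the scatter).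

Compound 4 `Cc1cn2c(/C=N/NC(=N)N)c(-c3ccccn3)nc2s1` has not yet been measured. It differs from compound 2 in one place: pyridin-2-yl in place of pyridin-3-yl on an aromatic carbon. The two have the same atoms, joined differently. Within the data shown here, only the step from compound 1 to compound 2 bears on this change, since it also moved the pyridine nitrogen, and it was a modest step. Among the measured compounds shown here, there is no measured step that tells how pyridin-2-yl behaves here, so the direction is open, and a step beyond the scatter in either direction is possible but a change of only modest size is expected, a 1.3-fold higher number from compound 2 to compound 4 (0.10 log units; within the scatter). For compound 4 the estimated value in this assay is 6000 nM, with a range from 2500 nM to 15000 nM.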

Compound 4, concentration for 50% growth inhibition: 3630 nM
Beside the measured number, compound 4's estimate is 1.7-fold (0.22 log units) above it; the measured number falls inside the stated range.
By their numbers in this assay, from the lowest: compounds 4 and 2 (each within the scatter of the next); then compounds 1 and 3 (each within the scatter of the next).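

With compound 4, all three pyridine attachments can be compared on the methyl-bearing core in this assay. Pyridin-2-yl in place of pyridin-3-yl gives a 1.3-fold lower number from compound 2 to compound 4 (0.12 log units; within the scatter), so on this read-out the two cannot be told apart, while pyridin-2-yl in place of pyridin-4-yl gives a 2.7-fold lower number from compound 1 to compound 4 (0.43 log units; beyond the scatter), and together with the earlier step this sets pyridin-4-yl apart from both other attachments at this position, with the higher number. Nothing available here explains why moving the pyridine nitrogen matters for one attachment and not for the other two.

Going by these compounds, it remains open whether the pyridine nitrogen matters at all at this position, which a plain phenyl ring would test, and whether a pyridine carrying an amine or a carboxylic acid would shift the number in either direction. Chloro on the core appears only with pyridin-3-yl, in compound 3, so it also remains unknown whether the change from methyl to chloro would have a similar effect alongside pyridin-2-yl.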